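Oxime ether chain extension: methyl to methoxy on the shared core

The source may report more compounds than this note shows. Statements on the series, on what has been measured and on what is new or still open speak of the compounds shown alone.

Measured compounds:
compound 1 `CCO/N=C/c1c(N)ncnc1Oc1ccc2[nH]c(C)cc2c1F` — 36 nM
compound 2 `CCCO/N=C/c1c(N)ncnc1Oc1ccc2[nH]c(C)cc2c1F` — 30 nM
compound 3 `CO/N=C/c1c(N)ncnc1Oc1ccc2cccnc2c1` — 2620 nM

In a functional assay on HCT-116 cells (Homo sapiens) for antiproliferative activity (a higher number here means a weaker inhibitor, a lower number a stronger inhibitor), compound 2 gives the lowest of the three numbers. Compound 1 sits nearest, within the scatter, while compound 3 lies far off; compound 3 differs from compound 2 in more than one place, so its value only marks how wide the range across the set is.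

The next compound, compound 4 `COCCO/N=C/c1c(N)ncnc1Oc1ccc2[nH]c(C)cc2c1F`, keeps the core of compound 2 and changes the chain on the oxime oxygen: methoxy in place of methyl on a saturated chain carbon, two bonds along the chain from an oxygen on an unsaturated carbon.

Among the compounds with values here, one measured step bears on this place. a 1.2-fold lower number from compound 1 to compound 2 (0.08 log units; within the scatter), a change at the same saturated chain carbon, and it left the number essentially where it was. Nothing measured here speaks to an oxygen entering at that position, so the expectation rests on that single step: the expected step is a 1.2-fold higher number from compound 2 to compound 4 (0.07 log units; within the scatter), none beyond the scatter.

For compound 4 the estimate in this assay is 35 nM, with a range from 15 nM to 85 nM.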

Compound 4, half-maximal inhibitory concentration: 387 nM
Compound 4: middle estimate off by 11-fold (1.04 log units), on the low side; the whole stated range lies below it.
By their numbers in this assay, from the lowest: compounds 2 and 1 (each within the scatter of the next); then compound 4; then compound 3.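

In this assay, the saturated chain carbon two bonds along the chain from an oxygen on an unsaturated carbon proves far less permissive than the earlier pair suggested: methoxy in place of methyl gives a 13-fold higher number from compound 2 to compound 4 (1.11 log units; beyond the scatter), and methoxy in place of hydrogen gives an 11-fold higher number from compound 1 to compound 4 (1.03 log units; beyond the scatter). The same carbon took methyl in place of hydrogen with only a 1.2-fold lower number from compound 1 to compound 2 (0.08 log units; within the scatter), so that tolerance of methyl does not carry over to methoxy. Nothing available here accounts for the loss.

The compounds shown do not separate the entering oxygen from the longer chain, and a butyl chain on the oxime oxygen, or a hydroxyl or an amine at the chain end, would bear on that. On these data alone, whether the same change gives a similar step on the core of compound 3 also stays open.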